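The source may report more compounds than this note shows. Statements on the series, on what has been measured and on what is new or still open speak of the compounds shown alone.

Working notes on the series. Compound 1 `CN1C(=O)COCC(NC(=O)OCc2ccccc2)C1=O` carries hydrogen on the saturated chain carbon bound to the amide-type nitrogen in the ring; in a functional assay on the whole organism (strain ICR) with Mus musculus as the target, in the maximal electroshock model, with a stated time of 30 min (a higher number here means that more compound is needed for the effect, a lower number that less compound is needed), compound 1 gives 68.8 mg/kg. Compound 2 `CCCCCCN1C(=O)COCC(NC(=O)OCc2ccccc2)C1=O` carries pentyl at that carbon, and in this assay compound 2 gives 87.5 mg/kg. Compound 3 `O=C(NC1COCC(=O)N(Cc2ccc(F)cc2)C1=O)OCc1ccccc1` carries 4-fluorophenyl at that carbon. In this assay compound 3 gives only a limit, > 100 mg/kg, not a number, and so stands at the limit of > 100 mg/kg in this assay, at which 1 of the 3 values shown sits. The steps of a 1.3-fold higher number from compound 1 to compound 2 (0.10 log units; within the scatter), an at least 1.4-fold higher number from compound 1 to compound 3 (0.16 log units; that floor lies within the scatter) and an at least 1.1-fold higher number from compound 2 to compound 3 (0.05 log units; that floor lies within the scatter) all show that changing the group at that carbon has moved the number little so far. Compound 4 `O=C(NC1COCC(=O)N(Cc2ccco2)C1=O)OCc1ccccc1` is not yet measured; it differs from compound 3 by furan-2-yl in place of 4-fluorophenyl on a saturated chain carbon bound to an amide-type nitrogen in a ring. Since every measured step at this position was small, the expected step of a number no higher from compound 3 to compound 4 (the limit leaves the size open) in this assay is none beyond the scatter. Compound 4 is therefore estimated at 100 mg/kg, with a range from 50 mg/kg to 200 mg/kg, and another limit rather than a number is considered likely.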

Compound 4, dose for half-maximal effect: > 100 mg/kg
Compound 4 ended at the assay's limit; the forecaster's own chance of this, stated with the estimate: 60%; the middle value sits exactly at the limit.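

In this assay, compound 3 and compound 4 both end at a limit rather than a number, so the step between them cannot be read: the limit of > 100 mg/kg in this assay, at which 2 of the 4 values shown sit. Against the compounds with numbers, furan-2-yl gives an at least 1.1-fold higher number from compound 2 to compound 4 (0.05 log units; that floor lies within the scatter) and an at least 1.4-fold higher number from compound 1 to compound 4 (0.16 log units; that floor lies within the scatter), so no step beyond the scatter is shown at this place yet. A six-membered aromatic ring of carbon only and a five-membered aromatic ring with a hetero atom, which brings a hydrogen-bond acceptor, now stand at the same limit on this carbon.

On these data alone, how far compound 3 and compound 4 lie past that limit remains open, and so does any difference between them. Also open, as far as these compounds go, is whether an amine, a carboxylic acid or a chain longer than pentyl at this place would give a step beyond the scatter.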